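Cyano in place of methyl: compound 3 to compound 4

The compounds below may be only part of what the source reports. "The series", "measured", "known", "first", "only" and "open" are said of these compounds alone.

In an ADME assay on microsomes from liver (Homo sapiens) for metabolic stability, read by LC-MS, with NADPH named in the record, with a stated time of 60 min, tested at 1 uM, in the absence of a further agent (a lower number here means that less of the compound is left, a higher number that more of the compound is left), compound 1 `COc1ccc(-c2c(C)nc3c(N4CC[C@@H](NC(C)=O)C4)cc(C)nn23)cc1OC` gives > 95% as a limit
Compound 2 `COc1ccc(-c2c(C)nc3c(N4CC[C@@H](NS(C)(=O)=O)C4)cc(C)nn23)cc1OC` gives > 95% as a limit
Compound 3 `COc1ccc(-c2c(C)nc3c(N4CC[C@@H](NS(=O)(=O)c5ccc(C)cc5)C4)cc(C)nn23)cc1OC` gives > 95% as a limit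

Compound 3 stands with only the limit > 95% to its name and has no number. The three compounds together show the limit of > 95% in this assay, at which 3 of the 3 values shown sit, and nothing ranks them. Compound 4 `COc1ccc(-c2c(C)nc3c(N4CC[C@@H](NS(=O)(=O)c5ccc(C#N)cc5)C4)cc(C)nn23)cc1OC` differs from compound 3 by cyano in place of methyl on an aromatic carbon, para to a large group, and the change counts as cyano in place of methyl on an aromatic carbon with the rest of the structure untouched. The measured steps closest to it are a step that the two limits leave unreadable from compound 2 to compound 3 and a step that the two limits leave unreadable from compound 1 to compound 3 and also a step that the two limits leave unreadable from compound 1 to compound 2 in the same part of the molecule. None of them has a readable size, yet none took a compound off the limit. The estimated a number no higher from compound 3 to compound 4 (the limit leaves the size open) in this assay is therefore expected to stay within the usual scatter, with no direction foreseen. Compound 4 is expected at 95% within a range of 82% to 100% on this estimate.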

Compound 4, percent of the compound remaining: > 95%
Compound 4: a limit, no number (the forecaster's own chance of this, stated with the estimate: 55%); the middle value sits exactly at the limit.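

In this assay compound 4 gives > 95%, a limit and not a number. No step from compound 1, compound 2 or compound 3 to compound 4 can be read: the limit of > 95% in this assay, at which 4 of the 4 values shown sit.

The compounds shown leave open whether these four differ at all in this read-out, and which change, if any, would take a compound off the limit.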